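This account rests on a few compounds, and the source may have more. Where it says the series, first, only, none or still open, it means among the compounds named here.

Measured so far in an assay on cells for displacement of a labelled ligand from Orexin receptor type 2 (Homo sapiens), read by scintillation counting, with stated times of 10 min and 90 min, tested at 10 uM; on this read-out lower numbers stand for less inhibition and higher numbers for more inhibition at the one concentration tested (going by the name of the read-out):
compound 1, `COC(=O)c1ccc2ccc(C(=O)c3ccccc3)c-2cc1`, 28.9%
compound 2, `COC(=O)c1ccc2c(I)cc(C(=O)c3ccccc3)c-2cc1`, -5.4%
compound 3, `CCOc1ccc(-c2cc(C(=O)c3ccccc3)c3ccc(C(=O)OC)ccc2-3)cc1`, 19.1%

Compound 1 gives the highest number of the three. The step of a number 9.8 percentage points lower from compound 1 to compound 3 (within the scatter) stays within the scatter, so compound 1 and compound 3 cannot be told apart on these numbers. The step of a number 34.3 percentage points lower from compound 1 to compound 2 (beyond the scatter) lies beyond it, so compound 2 inhibits less than compound 1. Between the two substituted compounds, the step of a number 24.5 percentage points higher from compound 2 to compound 3 (beyond the scatter) also lies beyond the scatter.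

Compound 4, `COC(=O)c1ccc2ccc(C=O)c-2cc1`, changes compound 1 at a different place: hydrogen in place of phenyl on a carbonyl carbon. Among the compounds with values here, none of the measured steps touches this carbonyl carbon; both change an aromatic carbon, and both lowered the number, one beyond the scatter and one within it. That gives only an indirect hint. Since a whole phenyl is removed rather than added, a change beyond the scatter seems more likely than not, and a drop appears more probable than a rise. Compound 4 is therefore estimated at 10%, with a range from -10% to 30%, an expected step of a number 18.9 percentage points lower from compound 1 to compound 4 (beyond the scatter).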

Compound 4, a percentage reported as inhibition, at one concentration (the size of the read-out at that concentration, not a potency): 37.2%
Compound 4: middle estimate off by 27.2 percentage points, on the low side; measured number outside the range, above it.
By their numbers in this assay, from the lowest: compound 2; then compounds 3, 1 and 4 (each within the scatter of the next, the first and the last beyond it).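

In this assay, replacing the phenyl on the carbonyl carbon with hydrogen gives a number 8.3 percentage points higher from compound 1 to compound 4 (within the scatter) and so leaves compound 1 and compound 4 indistinguishable on these numbers. The earlier steps shown here changed only an aromatic carbon, whereas this one shows that a whole phenyl can leave the carbonyl carbon without a change that can be told from the scatter at the one concentration tested. Nothing available here explains this result.

The compounds shown leave open how this carbonyl carbon would read with a group of another kind, such as a methyl, an amine or the hydroxyl of a carboxylic acid. They also leave open whether the iodo and 4-ethoxyphenyl changes would give similar steps with hydrogen rather than phenyl on the carbonyl carbon.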